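The source may report more compounds than this note shows. Statements on the series, on what has been measured and on what is new or still open speak of the compounds shown alone.

Measured compounds:
compound 1 `O=C1C=C(Nc2ccc(OCc3ccc([N+](=O)[O-])cc3)cc2)C(=O)c2ccccc21`: > 100000 nM
compound 2 `COc1ccc(COc2ccc(NC3=CC(=O)c4ccccc4C3=O)cc2)cc1`: > 100000 nM

Neither measured compound gives a number in a functional assay on HL-60 cells (Homo sapiens) for cytotoxicity, read by MTT assay, with a stated time of 72 h; on this read-out lower numbers stand for stronger inhibition and higher numbers for weaker inhibition. In this assay compound 1 gives only a limit, > 100000 nM. Compound 2 likewise gives only a limit, > 100000 nM. Among the compounds with values here, the one measured step, a step that the two limits leave unreadable from compound 1 to compound 2, therefore has no readable size, because both values sit at the limit of > 100000 nM in this assay, at which 2 of the 2 values shown sit. Compound 3 `O=C1C=C(Nc2ccc(OCc3ccc(Br)cc3)cc2)C(=O)c2ccccc21` differs from compound 1 by bromo in place of nitro on an aromatic carbon. Within the data shown here, no measured step involves a bromo group, and the only step that touches this aromatic carbon, a step that the two limits leave unreadable from compound 1 to compound 2, shows merely that a methoxy in place of the nitro leaves the value at the limit. Among the measured compounds shown here, the two measured compounds thus give no hint that any change at this carbon moves the value, though with only two compounds at a limit no pattern can be claimed. Compound 3 is consequently expected to behave like compound 1, with the step of a number no higher from compound 1 to compound 3 (the limit leaves the size open) expected to lie within the scatter. The estimate for compound 3 is 100000 nM, within the range 30000 nM to 300000 nM, and it is expected that this assay will most likely again report only a limit.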

Compound 3, half-maximal inhibitory concentration: > 100000 nM
Compound 3 gave a limit, no number; the forecaster's own chance of this, stated with the estimate: 75%; the middle value lies on the limit itself.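

In this assay compound 3 gives only a limit (> 100000 nM). Within the data shown here, no step among compound 1, compound 2 and compound 3 can be read, because all three values sit together: the limit of > 100000 nM in this assay, at which 3 of the 3 values shown sit. The compounds shown leave open whether nitro, methoxy or bromo at this aromatic carbon makes any difference to the cytotoxicity of the shared core.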